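The source may report more compounds than this note shows. Statements on the series, on what has been measured and on what is new or still open speak of the compounds shown alone.

Measured compounds:
Compound 1 `C=CC1=C(C(=O)O)C(c2ccc(F)cc2)OC1`: in a functional assay on QGY7701 cells (Homo sapiens) for cytotoxicity, read by MTT assay, with a stated time of 24 h (on this read-out lower numbers stand for stronger inhibition and higher numbers for weaker inhibition), compound 1 gives > 100000 nM, a limit of the assay.
Compound 2 `C=CC1=C(C(=O)O)C(c2ccc(OC)cc2)OC1`: in this assay compound 2 gives > 100000 nM, a limit of the assay.
Compound 3 `C=CC1=C(C(=O)NCCC)C(c2ccc(OC)c(OC)c2)OC1`: in this assay compound 3 gives > 100000 nM, a limit of the assay.

Among the measured compounds shown here, compound 2 thus stands at the limit, as does every value so far (the limit of > 100000 nM in this assay, at which 3 of the 3 values shown sit). For the measured compounds named here, the only measured step, a step that the two limits leave unreadable from compound 1 to compound 2, methoxy in place of fluoro on an aromatic carbon, is unreadable between two limits.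

Compound 4 `C=CC1=C(C(=O)NCC(C)C)C(c2ccc(OC)cc2)OC1` differs from compound 2 by isobutylamino in place of hydroxy on a carbonyl carbon. Going by the values given here, no measured step bears on this change: compound 3, itself a carboxamide, sits at the same limit, and a step that the two limits leave unreadable from compound 1 to compound 2 gives no size. Nothing in the data points to a step beyond the scatter in this assay in either direction. The step that the limit leaves unreadable from compound 2 to compound 4 is expected to be none beyond the scatter. Compound 4 is accordingly expected near 150000 nM, between 40000 nM and 600000 nM, most likely reported again as a limit.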

Compound 4, half-maximal inhibitory concentration: > 100000 nM
Compound 4 ended at the assay's limit; the forecaster's own chance of this, stated with the estimate: 80%; the middle value lies beyond the limit too.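

No new step can be read from compound 2 to compound 4, since both values are limits, as is every value in the series: the limit of > 100000 nM in this assay, at which 4 of the 4 values shown sit.

The compounds shown leave open whether any change on the shared core gives a measurable value in this assay.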